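A few compounds are considered here, and "the series" means these few. Any claim that something is new, unique, unknown or untested is made for them only; others in the source may bear on it.

Working notes on the series, read in a functional assay on HCT-15 cells (Homo sapiens) for cytotoxicity, read by ELISA, with a stated time of 2 days; a lower number here means a stronger inhibitor, a higher number a weaker inhibitor. Compound 1 (`Oc1cccc(-c2cc(-c3ccccc3)cc(-c3ccsc3)n2)c1`) gives 7660 nM, compound 2 (`Oc1ccccc1-c1cc(-c2ccccc2)nc(-c2ccco2)c1`) gives 2500 nM, and compound 3 (`Oc1cccc(-c2cc(-c3ccccc3)nc(-c3cccs3)c2)c1`) gives 14100 nM. Going by the values given here, compound 3 thus stands at the upper end of the numbers so far. Compound 1 lies within the scatter of it, while compound 2 lies beyond the scatter on the lower side.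

The next compound to be read is compound 4 (`Oc1cccc(-c2cc(-c3ccccc3)nc(-c3cccnc3)c2)c1`), which has pyridin-3-yl in place of thiophen-2-yl on an aromatic carbon, next to the ring nitrogen: pyridin-3-yl in place of thiophen-2-yl on an aromatic carbon.

Among the compounds with values here, no measured pair differs in one place only, so the data give no direct guide to this change. Since compound 3 at 14100 nM sits at the upper end, a small move towards a lower number in this assay is expected, not beyond the scatter. The expected step is a 1.6-fold lower number from compound 3 to compound 4 (0.19 log units; within the scatter). For compound 4 the estimate is 9000 nM, with an expected range of 3000 nM to 25000 nM.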

Compound 4, half-maximal inhibitory concentration: 18400 nM
Estimate against measurement, compound 4: 2.0-fold (0.31 log units) below; measured number inside the range.
By their numbers in this assay, from the lowest: compound 2; then compounds 1, 3 and 4 (each within the scatter of the next, the first and the last beyond it).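

In this assay, the series now has its first comparison that differs in one place: on an aromatic carbon next to the ring nitrogen, pyridin-3-yl in place of thiophen-2-yl gives a 1.3-fold higher number from compound 3 to compound 4 (0.12 log units; within the scatter) as its step. At this position, then, a six-membered aromatic ring with 1 hetero atom and a five-membered one read alike, even though the hetero atom changes from sulfur to nitrogen and the group gains a heavy atom. No measured information bears on why the two groups read alike.

Going by these compounds, whether a dimethylamino group or a carboxylic acid at this position would give a step beyond the scatter remains open. Also open, on these data alone, is whether the same exchange would read alike on a core that lacks the 3-hydroxyphenyl group.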